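The source may report more compounds than this note shows. Statements on the series, on what has been measured and on what is new or still open speak of the compounds shown alone.

Compound 1 `CCn1ccnc1-c1cc(OC)c(OC)c(OC)c1` gives in a functional assay on HeLa cells (Homo sapiens) for antiproliferative activity, read by MTT assay, with a stated time of 72 h (a higher number here means a weaker inhibitor, a lower number a stronger inhibitor), only a limit, > 100000 nM. Compound 2 `COc1cc(-c2nccn2CC(C)C)cc(OC)c1OC` likewise gives in this assay only a limit, > 100000 nM. Compound 2 thus stands at the limit of the assay, and this is all that is known of it: the limit of > 100000 nM in this assay, at which 2 of the 2 values shown sit. Going by the values given here, the single measured step, a step that the two limits leave unreadable from compound 1 to compound 2, is for that reason not readable; isopropyl in place of methyl on a saturated chain carbon bound to an aromatic nitrogen cannot be given a size from two limits.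

Compound 3 `COc1cc(-c2nccn2-c2ccc(F)cc2)cc(OC)c1OC` differs from compound 2 as follows: 4-fluorophenyl in place of isobutyl on an aromatic nitrogen. Among the compounds with values here, no measured step exchanges an alkyl group on this nitrogen for an aromatic one, so none bears on the change directly, and the one step known for this nitrogen gave no readable size. Any expectation rests only on both known values sitting at the limit. The step of a number no higher from compound 2 to compound 3 (the limit leaves the size open) from compound 2 to compound 3 is therefore expected to be no larger than the scatter, with a wide range around that guess. Compound 3 is estimated at 100000 nM, between 20000 nM and 300000 nM, with a substantial chance that this assay again reports only a limit.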

Compound 3, half-maximal inhibitory concentration: 17500 nM
For compound 3 the middle estimate is 5.7-fold (0.76 log units) above the measured one, and the stated range ends above it.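

In this assay, exchanging an alkyl group on this aromatic nitrogen for 4-fluorophenyl gives the first readable response in the series, with an at least 5.7-fold lower number from compound 2 to compound 3 (0.75 log units; beyond the scatter) and, against ethyl as the group that leaves, an at least 5.7-fold lower number from compound 1 to compound 3 (0.75 log units; beyond the scatter). Both steps are lower bounds only, because the alkyl compound at the start of each sits at a limit of the assay: the limit of > 100000 nM in this assay, at which 2 of the 3 values shown sit. The position is therefore not silent in this assay: ethyl and isobutyl cannot be told apart, and the step between them remains unreadable, whereas the 4-fluorophenyl group, with its six-membered aromatic ring of carbon only, gives a measured number on the same core.

Going by these compounds, whether the aromatic ring or its fluorine carries the step stays open, and plain phenyl, benzyl or 4-methoxyphenyl on the same nitrogen would separate the two. Also open, on these data alone, are how much further the number can fall below that of compound 3 and whether the step survives an amine or a carboxylic acid on the aromatic ring.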